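This account rests on a few compounds, and the source may have more. Where it says the series, first, only, none or still open, it means among the compounds named here.

The measured compounds:

Compound 1 `Cn1cc(-c2cnc3ccnc(N)c3c2)cn1`: 40800 nM
Compound 2 `Cc1ccc(S(=O)(=O)Nc2ccc3ncc(-c4cnn(C)c4)cc3n2)cc1`: > 50000 nM (a limit of the assay)
Compound 3 `Cn1cc(-c2cnc3ccnc(NC(=O)C4CC4)c3c2)cn1`: > 50000 nM (a limit of the assay)

In a functional assay on HeLa cells (Homo sapiens) for antiproliferative activity, read by MTT assay, with a stated time of 48 h (on this read-out higher numbers stand for weaker inhibition and lower numbers for stronger inhibition), compound 1 gives 40800 nM. Compound 2 reaches only a limit of the assay, > 50000 nM. Compound 3 likewise reaches only a limit, > 50000 nM. Compound 3 therefore stands at the weak end of what has been seen, at the limit of > 50000 nM in this assay, at which 2 of the 3 values shown sit. For the measured compounds named here, the one step measured so far, an at least 1.2-fold higher number from compound 1 to compound 3 (0.08 log units; that floor lies within the scatter), is itself only a floor, and that floor lies within the usual scatter, so it says little beyond the fact that the acylated compound is not stronger than the free amine.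

Compound 4 `Cn1cc(-c2cnc3ccnc(NC(=O)c4cccnc4)c3c2)cn1` is the next acyl variant. Compared with compound 3 the change is pyridin-3-yl in place of cyclopropyl on a carbonyl carbon. Going by the values given here, no measured step involves a pyridin-3-yl group, so nothing measured bears directly on this change; all that is known is that an acyl group on this nitrogen, in compound 3, left the value at the limit.

The estimate is therefore that compound 4 stays near that limit, with a number no higher from compound 3 to compound 4 (the limit leaves the size open) expected to be no step beyond the scatter, and its expected value is 50000 nM, in the range 10000 nM to 250000 nM.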

Compound 4, half-maximal inhibitory concentration: > 50000 nM
Compound 4 was reported as a limit (the forecaster's own chance of this, stated with the estimate: 60%); the middle value sits exactly at the limit.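

Swapping cyclopropyl for pyridin-3-yl on the carbonyl carbon brings in a six-membered aromatic ring with a hydrogen-bond acceptor, yet in this assay compound 4 still reaches only a limit of the assay, just as compound 3 does. So a second, quite different acyl group on this nitrogen gives no sign of stronger inhibition than the free amine, and the comparison with that amine gives an at least 1.2-fold higher number from compound 1 to compound 4 (0.08 log units; that floor lies within the scatter) and so only a floor, not a measured size. The step between the two acyl compounds cannot be read, and values at this position now gather at one edge of the measurable range: the limit of > 50000 nM in this assay, at which 3 of the 4 values shown sit.

The compounds shown leave open whether a small acetyl group, or a longer chain ending in an amine, on this nitrogen would give a readable number rather than a limit. They also leave open how far past the limit compound 3 and compound 4 lie, and so whether these two differ from each other at all.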